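The compounds below may be only part of what the source reports. "The series", "measured", "known", "first", "only" and "open" are said of these compounds alone.

Measured compounds:
- Compound 1, `CC(C)N(Cc1cccc(OCCCCCC(=O)O)c1)C(=O)c1ccc(-c2cccc(Oc3ccccc3)c2)cc1`: in an ADME assay on Raji cells (Homo sapiens) for cytotoxicity, read by CellTiter-Glo and resazurin assay, with a stated time of 72 h (a lower number here means that less compound is needed, a higher number that more compound is needed for the effect), compound 1 gives > 18700 nM, a limit rather than a number.
- Compound 2, `COc1cccc(-c2ccc(C(=O)N(Cc3cccc(OCCCCCC(=O)O)c3)C(C)C)cc2)c1`: compound 2 gives > 20900 nM, again a limit.
- Compound 3, `CC(C)N(Cc1cccc(OCCCCCC(=O)O)c1)C(=O)c1ccc(-c2ccc3[nH]ccc3c2)cc1`: compound 3 gives > 26000 nM, also a limit.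

Compound 3 therefore stands on a limit only (the limit of > 26000 nM in this assay, at which 1 of the 3 values shown sits), and the two other values shown are limits too (the limit of > 18700 nM in this assay, at which 1 of the 3 values shown sits, (the limit of > 20900 nM in this assay, at which 1 of the 3 values shown sits)). Compound 4, `CC(C)N(Cc1cccc(OCCCCCC(=O)O)c1)C(=O)c1ccc(-c2cccc(Br)c2)cc1`, differs from compound 3 by 3-bromophenyl in place of 1H-indol-5-yl on an aromatic carbon. The measured steps that bear on this ring exchange are a step that the two limits leave unreadable from compound 1 to compound 2 and a step that the two limits leave unreadable from compound 2 to compound 3; neither can be read, since both ends sit at limits. No readable step is expected in this assay, and compound 4 is expected to come out as a further limit, with an at least 1.0-fold lower number from compound 3 to compound 4 (0.01 log units; that floor lies within the scatter) meaning no change beyond the scatter; the estimate for compound 4 is 25000 nM, within 10000 nM to 60000 nM.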

Compound 4, half-maximal effective concentration: > 26000 nM
Compound 4: no number, only a limit; the forecaster's own chance of this, stated with the estimate: 85%; middle value at least 1.0-fold (0.01 log units) away from the limit.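

Compound 4 gives > 26000 nM in this assay, which is a limit. For the compounds shown here, no step from compound 1, compound 2 or compound 3 to compound 4 can be read, as all the values are limits. The compounds shown leave open what concentration of any of them gives the half-maximal effect.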